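Replacing the amide substituent of compound 1 with a short hydroxyalkyl chain

A few compounds are considered here, and "the series" means these few. Any claim that something is new, unique, unknown or untested is made for them only; others in the source may bear on it.

Compound 1 `CCn1c(C(=O)N[C@H](C)C(=O)OC)ccc1C(CC)(CC)c1ccc(OCS(=O)(=O)c2ccccc2)c(C)c1` was tested in a functional assay on MCF7 cells (Homo sapiens) for antiproliferative activity, read by MTT assay, with a stated time of 24 h; a lower number here means a stronger inhibitor, a higher number a weaker inhibitor. In this assay compound 1 gives only a limit, > 50000 nM, so its exact number is not known. The step to compound 4 `CCn1c(C(=O)NCCCO)ccc1C(CC)(CC)c1ccc(OCS(=O)(=O)c2ccccc2)c(C)c1` changes the group on the amide-type nitrogen: 3-hydroxypropyl in place of 1-(methoxycarbonyl)ethyl on an amide-type nitrogen. Two measured steps start from the same point. Compound 2 `CCN(CC)CCNC(=O)c1ccc(C(CC)(CC)c2ccc(OCS(=O)(=O)c3ccccc3)c(C)c2)n1CC` carries a 2-(diethylamino)ethyl group in that place and gives 4680 nM in this assay, a step of an at least 10-fold lower number from compound 1 to compound 2 (1.02 log units; beyond the scatter). Compound 3 `CCn1c(C(=O)N[C@@H](CO)C(C)C)ccc1C(CC)(CC)c1ccc(OCS(=O)(=O)c2ccccc2)c(C)c1` carries a 1-(hydroxymethyl)-2-methylpropyl group there and gives 18800 nM in this assay, a step of an at least 2.6-fold lower number from compound 1 to compound 3 (0.42 log units; beyond the scatter). Between these two, the step of a 4.0-fold higher number from compound 2 to compound 3 (0.60 log units; beyond the scatter) shows that the hydroxyl-bearing substituent sits at the weaker end. Compound 4 brings in a hydroxyl-bearing chain as well, so it seems closest to compound 3, and the expected step is an at least 2.2-fold lower number from compound 1 to compound 4 (0.35 log units; beyond the scatter), a lower number than the limit of compound 1 but not as low as compound 2. The estimated value for compound 4 in this assay is 22000 nM, with an expected range from 8000 nM to 60000 nM, because compound 3 gave 18800 nM with a related change.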

Compound 4, half-maximal inhibitory concentration: 42000 nM
Compound 4: the middle estimate sits 1.9-fold (0.28 log units) below what was measured; measured number inside the range.
By their numbers in this assay, from the lowest: compound 2; then compound 3; then compound 4. At a limit, above all of these: compound 1.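

In this assay the change gives an at least 1.1-fold lower number from compound 1 to compound 4 (0.07 log units; that floor lies within the scatter), a floor that rests on a limit and not on a number: the limit of > 50000 nM in this assay, at which 1 of the 4 values shown sits. The clearer news comes from the hydroxyl-bearing groups, which do not all give the same result on the amide-type nitrogen: the step of a 2.2-fold higher number from compound 3 to compound 4 (0.35 log units; beyond the scatter) separates 3-hydroxypropyl from 1-(hydroxymethyl)-2-methylpropyl by more than the scatter. The gap to the group carrying diethylamino is wider, at a 9.0-fold higher number from compound 2 to compound 4 (0.95 log units; beyond the scatter), so compound 2 now keeps the lowest number against two different hydroxyl-bearing groups.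

The compounds shown leave open whether diethylamino matters in particular or whether another amine on the same chain, such as dimethylamino or morpholine, would give a similar number. They also leave open how a 2-hydroxyethyl group or a longer hydroxyalkyl chain would compare with compound 4, and how a carboxylic acid in place of the methyl ester of compound 1 would read in this assay.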